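This account rests on a few compounds, and the source may have more. Where it says the series, first, only, none or still open, it means among the compounds named here.

Values measured in a functional assay on MCF7 cells (Homo sapiens) for cytotoxicity; a higher number here means that more compound is needed for the effect, a lower number that less compound is needed:
- Compound 1 `COc1ccc(/C=C/c2cc(OC)c(OCc3ccccc3)c(OC)c2)cc1`: > 25 uM (a limit, not a number)
- Compound 2 `CCOc1ccc(/C=C/c2cc(OC)c(OC)c(OC)c2)cc1`: 7.5 uM
- Compound 3 `CCOc1ccc(/C=C\c2cc(OC)c(OC)c(OC)c2)cc1`: 9.6 uM

Only compound 2 and compound 3 give actual numbers in this assay, and the two stand level. Compound 2, at 7.5 uM, has compound 3 as its nearest neighbour, with a 1.3-fold higher number from compound 2 to compound 3 (0.11 log units; within the scatter). The reading for compound 1 is a limit.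

Compound 4 `CCCOc1ccc(/C=C/c2cc(OC)c(OC)c(OC)c2)cc1` has not yet been measured. It departs from compound 2 by a single change on the ethoxy chain: methyl in place of hydrogen on a saturated chain carbon, two bonds along the chain from an oxygen on an aromatic ring. In short, ethoxy becomes propoxy.

For the measured compounds named here, the one measured step is a 1.3-fold higher number from compound 2 to compound 3 (0.11 log units; within the scatter). It offers only indirect guidance, given (the fact that compounds 2 and 3 differ only in the configuration as drawn), and the set holds no measured change of chain length. The expectation therefore starts from compound 2 at 7.5 uM, with a wide margin on either side. No shift beyond the scatter is expected in this assay, and neither direction is favoured by the data. The estimated change is a 1.2-fold higher number from compound 2 to compound 4 (0.08 log units; within the scatter). For compound 4 the estimated value is 9 uM, with an expected range of 3.5 uM to 25 uM.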

Compound 4, concentration for half-maximal effect: 12.5 uM
Estimate against measurement, compound 4: 1.4-fold (0.14 log units) below; the range from low to high includes it.
By their numbers in this assay, from the lowest: compounds 2, 3 and 4 (each within the scatter of the next). At a limit, above all of these: compound 1.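

In this assay the change from ethoxy to propoxy gives a 1.7-fold higher number from compound 2 to compound 4 (0.22 log units; within the scatter) and is the only change of chain length among the compounds shown, since the earlier step between measured compounds concerned configuration alone. It shows that methyl can take the place of hydrogen on this saturated chain carbon, two bonds along the chain from an oxygen on an aromatic ring, without a shift that stands clear of the usual scatter, so that compound 2 and compound 4 remain level in this assay. What is known about the compounds offers no explanation for this step and gives no reason to read more into it.

A single step of this size cannot show whether the same holds further out, so the compounds shown leave open what a longer chain such as butoxy, a branched chain such as isopropoxy, or a chain ending in an amine or a carboxylic acid would do at this position. They also leave open whether propoxy would behave the same way on a double bond drawn Z, as the step between the two ethoxy compounds covers only that chain.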